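The compounds below may be only part of what the source reports. "The series", "measured", "known", "first", "only" and "open" are said of these compounds alone.

Measured compounds: compound 1 `CCCCCCNC(=O)Oc1ccc(Cl)cc1C(=O)Nc1ccc(Cl)cc1`, which in an ADME assay for metabolic stability, read by HPLC, at pH 7 (a higher number here means that the compound lasts longer, a lower number that the compound disappears faster), gives 64 h; compound 2 `CCCCCCCCNC(=O)Oc1ccc(Cl)cc1C(=O)Nc1ccc(Cl)cc1`, which in this assay gives 64 h; compound 3 `CCCNC(=O)Oc1ccc(Cl)cc1C(=O)Nc1ccc(Cl)c(Cl)c1`, which in this assay gives 64 h.

The step from compound 1 to compound 2 is ethyl in place of hydrogen on a saturated chain carbon, six bonds along the chain from an amide-type nitrogen, and in this assay it gave no change at the digits printed from compound 1 to compound 2 (within the scatter). Compound 3 carries a core whose difference from the core of compound 1 is not broken down here; its value sits level with compound 1 and compound 2 within the scatter. Compound 4 `CCCCCNC(=O)Oc1ccc(Cl)cc1C(=O)Nc1ccc(Cl)c(Cl)c1`, not yet measured, differs from compound 3 by ethyl in place of hydrogen on a saturated chain carbon, three bonds along the chain from an amide-type nitrogen. This is the same kind of change as that from compound 1 to compound 2, but the place differs: there the ethyl enters six bonds along the chain from an amide-type nitrogen, here three bonds along. Resting on the flat step from compound 1 to compound 2 in this assay, compound 4 is expected to show no change at the digits printed from compound 3 to compound 4 (within the scatter). Compound 4 is thus estimated at 64 h, between 32 h and 128 h.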

Compound 4, half-life: 64 h
The estimate for compound 4 equals the measured number at the digits printed, and the stated range covers the measured number.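

In this assay, ethyl in place of hydrogen gave no change at the digits printed from compound 3 to compound 4 (within the scatter), and set beside the earlier step, the change carries over between these two cores: the same change on two cores in this assay, no change at the digits printed (within the scatter) from compound 1 to compound 2 and no change at the digits printed (within the scatter) from compound 3 to compound 4, 1.0-fold (0.00 log units) apart, within the scatter of two such steps. This does not show that the change is silent on other cores, and core and place cannot be told apart here, as the ethyl enters six bonds along the chain on one core and three bonds along on the other. Two flat steps also say nothing about how a step of real size would carry over.

The compounds shown leave open whether a chain ending in an amine or a carboxylic acid would stay level with these values. From the compounds shown here alone, a branched chain or a cyclohexyl ring in place of the straight chain remains equally open.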